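This account rests on a few compounds, and the source may have more. Where it says the series, first, only, none or still open, it means among the compounds named here.

Compound 1 `COc1ccc(C(=O)OC(CCN(C)C)c2ccc(Cl)cc2)cc1` and compound 2 `CN(C)CCC(OC(=O)c1ccc(C(F)(F)F)cc1)c1ccc(Cl)cc1` share one core and differ in a single group: trifluoromethyl in place of methoxy on an aromatic carbon. In an assay on NIH3T3 cells with Urotensin-2 receptor (Homo sapiens) as the target (a lower number here means that less compound is needed, a higher number that more compound is needed for the effect), compound 1 gives 2190 nM, while compound 2 gives 1740 nM, so the step of a 1.3-fold lower number from compound 1 to compound 2 (0.10 log units; within the scatter). Compound 3 `COc1ccc(C(=O)NC(CCN(C)C)c2ccc(Cl)cc2)cc1` carries a different core; the difference between the two cores is not broken down here. In this assay compound 3 gives 1350 nM, and its values and those of compound 1 and compound 2 all lie within the scatter of one another. Compound 4 `CN(C)CCC(NC(=O)c1ccc(C(F)(F)F)cc1)c1ccc(Cl)cc1` repeats the same change on the core of compound 3: trifluoromethyl in place of methoxy on an aromatic carbon. Because the step of a 1.3-fold lower number from compound 1 to compound 2 (0.10 log units; within the scatter) stayed within the scatter, the step from compound 3 to compound 4 is expected to be similar, a 1.3-fold lower number from compound 3 to compound 4 (0.11 log units; within the scatter). For compound 4 in this assay the estimate is 1050 nM, with a range from 450 nM to 2500 nM.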

Compound 4, half-maximal effective concentration: 77.6 nM
Compound 4: middle estimate off by 14-fold (1.13 log units), on the high side; measured number outside the range, below it.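

In this assay, putting trifluoromethyl in place of methoxy on the core of compound 3 gives a 17-fold lower number from compound 3 to compound 4 (1.24 log units; beyond the scatter), and this step does not match the one seen for the same change on the core of compound 1: the same change on two cores in this assay, a 1.3-fold lower number (0.10 log units; within the scatter) from compound 1 to compound 2 and a 17-fold lower number (1.24 log units; beyond the scatter) from compound 3 to compound 4, 14-fold (1.14 log units) apart, beyond the scatter of two such steps So in this series, the size of this step on one core did not predict its size on the other. The result does not show why the two cores differ, and two pairs give no general rule for other cores.

The compounds shown leave open how a nitrile or a methyl group on the same aromatic carbon would behave on each core. They also leave open whether a further core would follow compound 3 and compound 4 or compound 1 and compound 2.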